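The source may hold more compounds than are shown below. What is called first, only, known or untested is meant among the compounds shown, and "the series" means these compounds.

Measured in a functional assay for inhibition, with Homo sapiens as the target; a lower number here means a stronger inhibitor, a higher number a weaker inhibitor:
- compound 1 `O=C(/C=C/c1ccccc1)c1ccccc1OCc1ccccc1`: 2230 nM
- compound 2 `COC(=O)c1ccccc1C(=O)/C=C/c1ccccc1`: 1950 nM

Among the measured compounds shown here, only these two compounds have numbers so far. For the measured compounds named here, compound 2 stands at 1950 nM and its one neighbour, compound 1, at 2230 nM. The a 1.1-fold lower number from compound 1 to compound 2 (0.06 log units; within the scatter) lies within the scatter, so the two cannot be told apart.

The next compound to be measured is compound 3 `CN(C)C(=O)c1ccccc1C(=O)/C=C/c1ccccc1`. It keeps the core of compound 2 and changes one group: dimethylamino in place of methoxy on a carbonyl carbon, which turns methoxycarbonyl into dimethylcarbamoyl (dimethylamino in place of methoxy on a carbonyl carbon).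

Going by the values given here, no measured step covers a change at this carbonyl carbon. Among the compounds with values here, the only step that bears on it is a 1.1-fold lower number from compound 1 to compound 2 (0.06 log units; within the scatter), a swap of methoxycarbonyl for benzyloxy on an aromatic carbon, and it stayed within the scatter. That is thin evidence, but it gives no reason to expect a move in either direction in this assay. The expected 1.1-fold higher number from compound 2 to compound 3 (0.03 log units; within the scatter) is therefore no larger than the scatter. For compound 3 the estimated value is 2100 nM, with an expected range from 800 nM to 5500 nM.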

Compound 3, half-maximal inhibitory concentration: 5500 nM
Estimate against measurement, compound 3: 2.6-fold (0.42 log units) below; the measured number falls inside the stated range.
By their numbers in this assay, from the lowest: compounds 2 and 1 (each within the scatter of the next); then compound 3.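

In this assay, among the compounds shown here, dimethylamino in place of methoxy on a carbonyl carbon is the first change in this short series to move the number beyond the scatter, with a 2.8-fold higher number from compound 2 to compound 3 (0.45 log units; beyond the scatter). The same holds against the benzyloxy compound, with a 2.5-fold higher number from compound 1 to compound 3 (0.39 log units; beyond the scatter), so this place on the shared core does respond to the group it carries, even though methoxycarbonyl and benzyloxy could not be told apart there, and compound 3 is the weakest inhibitor of the three. No measurement at hand explains why dimethylcarbamoyl gives the higher number.

The compounds shown leave open whether the higher number belongs to the amide nitrogen as such or to the dimethylamino group as a whole, which methylamino or a plain amino group on the same carbonyl carbon would help to separate. Also open, on these data alone, is how a carboxylic acid at this place, or a longer ester such as ethoxycarbonyl, would compare with compound 2 in this assay.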